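A Methyl Added to the Aromatic Ring of Compound 1

This account rests on a few compounds, and the source may have more. Where it says the series, first, only, none or still open, it means among the compounds named here.

Compound 1, `C[C@@H]1CN(c2scnc2-c2nc3ccccc3[nH]2)CCN1C(=O)Cn1cnc2cccnc21`: 830 nM
Compound 2, `C[C@H]1CN(c2scnc2-c2nc3ccccc3[nH]2)CCN1C(=O)Cn1cnc2cccnc21`: 8030 nM
Compound 3, `CC[C@@H]1CN(c2scnc2-c2nc3ccccc3[nH]2)CCN1C(=O)Cn1cnc2cccnc21`: 604 nM

In a functional assay on U2OS cells for antagonist activity at C-X-C chemokine receptor type 3 (Homo sapiens), read by beta-arrestin recruitment (on this read-out higher numbers stand for weaker inhibition and lower numbers for stronger inhibition), compound 1 sits second highest of the three numbers. Its nearest value is that of compound 3, which adds a methyl in place of hydrogen on a saturated chain carbon bound to a saturated ring carbon: a 1.4-fold lower number from compound 1 to compound 3 (0.14 log units; within the scatter). Its furthest value is that of compound 2: a 9.7-fold higher number from compound 1 to compound 2 (0.99 log units; beyond the scatter), a step that rests on (the fact that compounds 1 and 2 differ only in the configuration as drawn). Compound 4 `Cc1nc(-c2nc3ccccc3[nH]2)c(N2CCN(C(=O)Cn3cnc4cccnc43)[C@H](C)C2)s1` carries methyl in place of hydrogen on an aromatic carbon. Neither measured step touches this aromatic carbon; the one small addition seen, in compound 3, stayed within the scatter. A step within the scatter is therefore expected, a 1.2-fold lower number from compound 1 to compound 4 (0.07 log units; within the scatter). Compound 4 is estimated at 700 nM, between 250 nM and 2500 nM.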

Compound 4, half-maximal inhibitory concentration: 1050 nM
Estimate against measurement, compound 4: 1.5-fold (0.18 log units) below, within the range that was stated.
By their numbers in this assay, from the lowest: compounds 3, 1 and 4 (each within the scatter of the next); then compound 2.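

In this assay, a methyl on the aromatic carbon next to the ring nitrogen and next to the ring sulfur gives a 1.3-fold higher number from compound 1 to compound 4 (0.10 log units; within the scatter), and neither earlier step touched this carbon. This aromatic carbon therefore carries a methyl with no step beyond the scatter. Nothing shown here accounts for this result.

From the compounds shown here alone, whether a longer chain, an amine or a carboxylic acid at this carbon would keep the number in the same range stays open. So does whether the methyl would give a similar step in the configuration of compound 2.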